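A few compounds are considered here, and "the series" means these few. Any claim that something is new, unique, unknown or untested is made for them only; others in the source may bear on it.

Measured so far:
- compound 1 `COc1ccc(Cl)cc1S(=O)(=O)NC(=O)NC/C=C1\CCCc2cnn(Cc3ccc(Cl)cc3Cl)c21` — 3 nM
- compound 2 `CS(=O)(=O)c1ccc(-n2ncc3c2/C(=C/CNC(=O)NS(=O)(=O)c2cc(Cl)c(Cl)s2)CCC3)cc1` — 1 nM

Both were read in an assay on isolated protein for displacement of a labelled ligand from prostaglandin E2 receptor EP3 subtype (Homo sapiens), read by scintillation counting, with a stated time of 2 h; on this read-out lower numbers stand for stronger inhibition and higher numbers for weaker inhibition. Of the two numbers, compound 1 carries the higher one; compound 2 sits at a lower number, and that gap is beyond the usual scatter. Within the data shown here, no stepwise pair of measured compounds is available in this set.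

Compound 3 `COc1ccccc1S(=O)(=O)NC(=O)NC/C=C1\CCCc2cnn(Cc3ccc(Cl)cc3Cl)c21` differs from compound 1 in one place: hydrogen in place of chloro on an aromatic carbon. No measured comparison covers this change. The step from compound 1 to compound 3 is expected to be a modest rise, a 2.7-fold higher number from compound 1 to compound 3 (0.43 log units; beyond the scatter), possibly just beyond the scatter. Compound 3 is estimated at 8 nM, within 3 nM to 25 nM.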

Compound 3, inhibition constant: 62 nM
The estimate for compound 3 lay 7.8-fold (0.89 log units) below the measured number; measured number outside the range, above it.
By their numbers in this assay, from the lowest: compound 2; then compound 1; then compound 3.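

In this assay the change from 5-chloro-2-methoxyphenyl to 2-methoxyphenyl gives a 21-fold higher number from compound 1 to compound 3 (1.32 log units; beyond the scatter), a large step beyond the scatter. The earlier compounds shown here could not show that this place, para to the methoxy group, is so sensitive: loss of one chlorine atom alone produces the step. Nothing measured here accounts for its size.

As far as these compounds go, whether bromo, methyl or an amine at this carbon would keep the number of compound 1 remains open. Also open, from the compounds shown here alone, is whether removing chloro has a similar effect in other members.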